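The source may report more compounds than this note shows. Statements on the series, on what has been measured and on what is new or still open speak of the compounds shown alone.

Measured so far:
compound 1, `CCN(CC)c1nc(Nc2cccc([N+](=O)[O-])c2)nc(OC(C(F)(F)F)C(F)(F)F)n1` — 200 nM
compound 2, `CCN(CC)c1nc(Nc2ccc(C(=O)O)cc2)nc(OC(C(F)(F)F)C(F)(F)F)n1` — 900 nM

Within the data shown here, in an assay on cells for activation of Cystic fibrosis transmembrane conductance regulator (Homo sapiens), read by fluorescence, with stated times of 10 min and 12 s (on this read-out higher numbers stand for an effect only at larger amounts of compound and lower numbers for an effect already at smaller amounts), compound 2 has the higher of the two numbers; the only measured step, a 4.5-fold higher number from compound 1 to compound 2 (0.65 log units; beyond the scatter), runs toward it. Compound 3, `CCN(CC)c1nc(Nc2ccc(F)cc2)nc(OC(C(F)(F)F)C(F)(F)F)n1`, differs from compound 2 by fluoro in place of carboxy on an aromatic carbon. Among the measured compounds shown here, no measured step covers this exchange; the one available step shows only that changing the group on this phenyl ring moves the number beyond the scatter. Removing the carboxy is therefore expected to shift the number back toward that of compound 1, a modest step of a 2.3-fold lower number from compound 2 to compound 3 (0.35 log units; beyond the scatter). For compound 3 the estimate is 400 nM, between 150 nM and 1200 nM.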

Compound 3, half-maximal effective concentration: 700 nM
Estimate against measurement, compound 3: 1.8-fold (0.24 log units) below; measured number inside the range.
By their numbers in this assay, from the lowest: compound 1; then compounds 3 and 2 (each within the scatter of the next).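

In this assay, fluoro in place of carboxy gives a 1.3-fold lower number from compound 2 to compound 3 (0.11 log units; within the scatter) and so leaves the number at this para carbon within the scatter, despite the loss of the hydrogen-bond donor and acceptor counted for carboxy. The 4-fluorophenyl group, like the 4-carboxyphenyl group, stays apart from the 3-nitrophenyl group of compound 1, with a 3.5-fold higher number from compound 1 to compound 3 (0.54 log units; beyond the scatter) as the new step. No measured evidence accounts for either result.

On these data alone, it remains open whether the gap to compound 1 belongs to the nitro group or to where it sits on the ring, which a 4-nitrophenyl or 3-fluorophenyl group would separate. As far as these compounds go, how an amine on this carbon would read also remains open.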